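A few compounds are considered here, and "the series" means these few. Any claim that something is new, unique, unknown or untested is made for them only; others in the source may bear on it.

In a functional assay on SW-620 cells (Homo sapiens) for cytotoxicity, read by colorimetric assay (on this read-out higher numbers stand for weaker inhibition and lower numbers for stronger inhibition), compound 1 (`O=C(/C=C/c1ccc(CN2C(=O)/C(=C3\Nc4ccccc4\C3=N/O)c3cccc(Cl)c32)cc1)NO`) gives 60 nM and compound 2 (`Cc1ccc2c(c1)/C(=C1/Nc3ccccc3/C1=N\O)C(=O)N2Cc1ccc(/C=C/C(=O)NO)cc1`) gives 50 nM, two numbers within the scatter of each other at the upper end of the measured set. Compound 3 (`O=C(NO)c1ccc(CN2C(=O)/C(=C3\Nc4ccccc4\C3=N/O)c3cc(F)ccc32)cc1`) gives 20 nM, a number lower than that of compound 1 by more than the scatter. Compound 4 (`O=C(NO)c1ccc(CN2C(=O)/C(=C3\Nc4ccccc4\C3=N/O)c3cccc(Cl)c32)cc1`) carries hydroxycarbamoyl in place of 2-(hydroxycarbamoyl)ethenyl on an aromatic carbon, para to a large group (hydroxycarbamoyl in place of 2-(hydroxycarbamoyl)ethenyl on an aromatic carbon). Within the data shown here, no measured pair isolates this change. Compound 3, at 20 nM, also bears hydroxycarbamoyl, so a modest fall in this assay is expected, possibly not beyond the scatter. The expected step is a 1.7-fold lower number from compound 1 to compound 4 (0.23 log units; within the scatter). For compound 4 the estimated value is 35 nM, within an expected range from 12 nM to 100 nM.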

Compound 4, half-maximal inhibitory concentration: 90 nM
Beside the measured number, compound 4's estimate is 2.6-fold (0.41 log units) below it; low and high end bracket the measured number.
By their numbers in this assay, from the lowest: compound 3; then compounds 2, 1 and 4 (each within the scatter of the next).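

In this assay, putting hydroxycarbamoyl in place of 2-(hydroxycarbamoyl)ethenyl on the aromatic carbon para to a large group gives a 1.5-fold higher number from compound 1 to compound 4 (0.18 log units; within the scatter) and this step lies within the scatter. Among these compounds, this pair is the first to isolate the change, and on the core of compound 1 the exchange moves the number by no more than repeated measurements would. Nothing available on these compounds accounts for this result. As far as these compounds go, whether the exchange behaves alike on other substituted cores stays open, as does the effect of a carboxylic acid or a longer chain bearing hydroxycarbamoyl on this carbon.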